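This account rests on a few compounds, and the source may have more. Where it says the series, first, only, none or still open, it means among the compounds named here.

Within the data shown here, compound 2 `c1c[nH]c(-c2ccccc2OCC2=NCCN2)c1` stands lowest of the two values so far in a functional assay for activation of Alpha-1B adrenergic receptor (Homo sapiens), read by calcium flux (a lower number here means a smaller maximal response, a higher number a larger maximal response), where compound 2 gives 104%. Its nearest neighbour is compound 1 `c1cncc(-c2ccccc2OCC2=NCCN2)c1`, which in this assay gives 111%; the step of a number 7 percentage points lower from compound 1 to compound 2 (within the scatter) lies within the usual scatter, so the two compounds cannot be told apart on this read-out. Compound 3 `c1ccc(-c2cc[nH]n2)c(OCC2=NCCN2)c1` is still unmeasured. Its structure differs from that of compound 2 in one place: 1H-pyrazol-3-yl in place of 1H-pyrrol-2-yl on an aromatic carbon. Among the measured compounds shown here, the only measured step that bears on this change is the one from compound 1 to compound 2, which also exchanged the aromatic ring sitting on that same aromatic carbon, and it amounted to a number 7 percentage points lower from compound 1 to compound 2 (within the scatter). On that basis no shift beyond the scatter is expected, and compound 3 is estimated to give a maximal response in this assay of about 105%, most likely between 85% and 125%. This estimate corresponds to an expected step of a number 1 percentage points higher from compound 2 to compound 3 (within the scatter).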

Compound 3, largest response reached (reported as maximum), in percent of the reference or control that the assay uses: 39%
The estimate for compound 3 lay 66 percentage points above the measured number; the measured number lies below the stated range.
By their numbers in this assay, from the lowest: compound 3; then compounds 2 and 1 (each within the scatter of the next).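

Here this assay shows a number 65 percentage points lower from compound 2 to compound 3 (beyond the scatter), and likewise a number 72 percentage points lower from compound 1 to compound 3 (beyond the scatter), so the aromatic ring on this carbon, ortho to a group of 7 heavy atoms, cannot be exchanged freely. The change that matters can look small on paper: 1H-pyrrol-2-yl and 1H-pyrazol-3-yl both have 5 heavy atoms and 1 hydrogen-bond donor, while the entering ring has 2 hetero atoms and 1 hydrogen-bond acceptor. Nothing available explains why the response falls.

Among these compounds, with only three compounds, it remains open whether the drop is specific to 1H-pyrazol-3-yl or would also appear with another ring, such as 1H-imidazol-2-yl or a thiophene. On these data alone, it is equally open how a plain phenyl ring at this carbon would behave.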